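This account rests on a few compounds, and the source may have more. Where it says the series, first, only, none or still open, it means among the compounds named here.

Compound 1 `COc1ccc(S(=O)(=O)N(Cc2cc(C)on2)[C@H](C)C(=O)NO)cc1`: in an assay on isolated protein for inhibition of bone morphogenetic protein 1 (Homo sapiens) (on this read-out higher numbers stand for weaker inhibition and lower numbers for stronger inhibition), compound 1 gives 230 nM.
Compound 2 `COc1ccc(S(=O)(=O)N(Cc2cccc3ccccc23)[C@H](C)C(=O)NO)cc1`: in this assay compound 2 gives 90 nM.

For the measured compounds named here, of these two numbers, compound 1 holds the highest; its only neighbour, compound 2, sits at a lower number by a margin beyond the usual scatter. Compound 3 `COc1ccc(S(=O)(=O)N(Cc2ccc(F)c(F)c2)[C@H](C)C(=O)NO)cc1` has not yet been measured. It differs from compound 1 in one place: 3,4-difluorophenyl in place of 5-methyl-1,2-oxazol-3-yl on a saturated chain carbon bound to a sulfonamide nitrogen. Going by the values given here, no measured pair shows this same change, so there is no step to lean on. A modest move toward lower numbers in this assay is expected, namely a 1.9-fold lower number from compound 1 to compound 3 (0.28 log units; within the scatter). Compound 3 is estimated at 120 nM, with a range from 50 nM to 300 nM.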

Compound 3, half-maximal inhibitory concentration: 76 nM
For compound 3 the middle estimate is 1.6-fold (0.20 log units) above the measured one, and the stated range covers the measured number.
By their numbers in this assay, from the lowest: compounds 3 and 2 (each within the scatter of the next); then compound 1.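

On a saturated chain carbon bound to a sulfonamide nitrogen, 3,4-difluorophenyl in place of 5-methyl-1,2-oxazol-3-yl gives, in this assay, a 3.0-fold lower number from compound 1 to compound 3 (0.48 log units; beyond the scatter). For the compounds shown here, this is the first step read directly at this position, and it shows that the choice of ring here moves the number by more than the usual scatter. Nothing at hand explains this gain. Still open, going by these compounds, is what an unsubstituted phenyl or a phenyl carrying a carboxylic acid would give at this place. The part played by the two fluorines therefore remains unsettled.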